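Acetoxyphenyl for methyl: compound 2 to compound 4

The source may report more compounds than this note shows. Statements on the series, on what has been measured and on what is new or still open speak of the compounds shown alone.

Measured in an ADME assay on L6 cells (Rattus norvegicus) for cytotoxicity, read by resazurin assay, with a stated time of 5 days; on this read-out lower numbers stand for higher toxicity in this test and higher numbers for lower toxicity in this test
compound 1 `CN1C(=O)/C(=C/N2N=C(c3ccc4ccccc4c3)CC2c2ccc(Cl)cc2)SC1=S` gives 154000 nM
compound 2 `COc1ccc(C2CC(c3ccc4ccccc4c3)=NN2/C=C2\SC(=S)N(C)C2=O)cc1` gives 175000 nM
compound 3 `CC(=O)Oc1cccc(N2C(=O)/C(=C/N3N=C(c4ccccc4)CC3c3ccccc3O)SC2=S)c1` gives 13600 nM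

Compound 2 stands at the top of the three numbers, level within the scatter with compound 1 and well clear of compound 3. The change to compound 4 `COc1ccc(C2CC(c3ccc4ccccc4c3)=NN2/C=C2\SC(=S)N(c3cccc(OC(C)=O)c3)C2=O)cc1` is 3-acetoxyphenyl in place of methyl on an amide-type nitrogen in a ring. Within the data shown here, the one measured step (a 1.1-fold higher number from compound 1 to compound 2 (0.06 log units; within the scatter)) concerns another place and stays within the scatter, so it says nothing on this change. Compound 3 carries the same 3-acetoxyphenyl and gives 13600 nM but also differs elsewhere, so it offers only a loose guide. A clear move to a lower number is therefore expected, stopping short of compound 3, and the estimated step is a 5.8-fold lower number from compound 2 to compound 4 (0.77 log units; beyond the scatter) in this assay overall. The estimate for compound 4 is 30000 nM (expected range 10000 nM to 90000 nM).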

Compound 4, half-maximal cytotoxic concentration: > 172000 nM
Compound 4: a limit, no number (the forecaster's own chance of this, stated with the estimate: 5%); middle value at least 5.7-fold (0.75 log units) from the limit.
By their numbers in this assay, from the lowest: compound 3; then compounds 1 and 2 (each within the scatter of the next).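

In this assay compound 4 gives > 172000 nM which is a limit and not a number, so the step from compound 2 to compound 4 cannot be read. As far as these compounds go, whether 3-acetoxyphenyl in place of methyl on this amide-type nitrogen shifts the read-out at all stays open.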